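Swapping the 4-chlorophenyl group on a fast-cleared compound

The source may hold more compounds than are shown below. What is called first, only, known or untested is meant among the compounds shown, and "the series" means these compounds.

Measured in an ADME assay (liver) for metabolic stability, with Liver microsome (Rattus norvegicus) as the target, using microsomes; on this read-out lower numbers stand for slow clearance and higher numbers for fast clearance:
- Compound 1 `O=C(O)c1csc(-n2nc(-c3ccccc3)c3cccnc32)n1`: 65 mL/min/kg
- Compound 2 `O=C(O)c1csc(-n2nc(-c3ccccc3)c3ccc(O)cc32)n1`: 522 mL/min/kg
- Compound 3 `O=C(O)c1csc(-n2nc(-c3ccc(Cl)cc3)c3ccccc32)n1`: 753 mL/min/kg

Compound 3, at 753 mL/min/kg, lies within the scatter of compound 2, at 522 mL/min/kg. Compound 1 gives 65 mL/min/kg. The gap from compound 1 up to compound 3 lies well beyond the scatter. The next compound to be tested is compound 4 `CC1CCN(c2nn(-c3nc(C(=O)O)cs3)c3ccccc23)CC1`. It departs from compound 3 by one change, 4-methylpiperidin-1-yl in place of 4-chlorophenyl on an aromatic carbon. Among the compounds with values here, no two measured compounds differ in only one place, so the data give no direct guide to this swap. Compound 4 keeps the core of compound 3, whereas the core of compound 1 differs, so the expectation leans on compound 3 and stays in the same high range. The expected change is a 1.4-fold lower number from compound 3 to compound 4 (0.14 log units; within the scatter), a small downward move that is not expected to go beyond the scatter. For compound 4 the estimated clearance in this assay is 550 mL/min/kg, with an expected range from 220 mL/min/kg to 1200 mL/min/kg.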

Compound 4, clearance: 260 mL/min/kg
The estimate for compound 4 lay 2.1-fold (0.33 log units) above the measured number; the range from low to high includes it.
By their numbers in this assay, from the lowest: compound 1; then compounds 4, 2 and 3 (each within the scatter of the next, the first and the last beyond it).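

Within the data shown here, this is the first step that isolates a single place: on the aromatic carbon of the five-membered aromatic ring with 2 nitrogen, 4-methylpiperidin-1-yl in place of 4-chlorophenyl gives a 2.9-fold lower number from compound 3 to compound 4 (0.46 log units; beyond the scatter) in this assay and this modest step lies beyond the scatter. So the read-out responds to the group at this place, and it does so with the heavy-atom count unchanged, as an all-carbon aromatic ring gives way to a non-aromatic ring holding a nitrogen. Nothing measured here accounts for the fall in the number.

The compounds shown leave open whether the step follows the ring nitrogen, the loss of the aromatic ring or the methyl group, which a plain piperidin-1-yl, a morpholin-4-yl or a cyclohexyl at this place could separate. They also leave open whether the same swap would carry over to the core of compound 1.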